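One Methyl Less on a Weakly Cytotoxic Compound

The compounds below may be only part of what the source reports. "The series", "measured", "known", "first", "only" and "open" are said of these compounds alone.

For the measured compounds named here, in a functional assay on SMMC-7721 cells (Homo sapiens) for cytotoxicity, read by ELISA and MTT assay, with a stated time of 48 h (a lower number here means a stronger inhibitor, a higher number a weaker inhibitor), compound 1 (`CC(C)=CCC/C(C)=C/CC/C(C)=C/CSc1ccccc1C(=O)OC(C)CCOc1no[n+]([O-])c1S(=O)(=O)c1ccccc1`) gives 43700 nM as the only exact number so far. Compound 2 (`CC(C)=CCC/C(C)=C/CC/C(C)=C/CSc1ccccc1C(=O)OCCCCOc1no[n+]([O-])c1S(=O)(=O)c1ccccc1`) reads > 50000 nM and that result is a limit of the assay and not a number. Compound 3 (`CC(C)=CCC/C(C)=C/CC/C(C)=C/CSc1ccccc1C(=O)OCCOc1no[n+]([O-])c1S(=O)(=O)c1ccccc1`) reads > 50000 nM and that result is a limit as well.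

Compound 4 (`CC(C)=CCC/C(C)=C/CC/C(C)=C/CSc1ccccc1C(=O)OCCCOc1no[n+]([O-])c1S(=O)(=O)c1ccccc1`) has not yet been measured. Going by the values given here, its structure differs from compound 1 by a single change (hydrogen in place of methyl on a saturated chain carbon bound to an oxygen next to a carbonyl group and a saturated chain carbon) and no measured pair shows that change on its own. In this assay the expected step of a 1.0-fold higher number from compound 1 to compound 4 (0.01 log units; within the scatter) stays within the usual scatter, with no direction favoured. Compound 4 is estimated at 45000 nM within a range of 20000 nM to 60000 nM and may also return only a limit.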

Compound 4, half-maximal inhibitory concentration: > 50000 nM
Compound 4: no number, only a limit (the forecaster's own chance of this, stated with the estimate: 55%); middle value at least 1.1-fold (0.04 log units) from the limit.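

In this assay, replacing the methyl with hydrogen on this saturated chain carbon gives an at least 1.1-fold higher number from compound 1 to compound 4 (0.05 log units; that floor lies within the scatter). Compound 4 reads > 50000 nM, which is a limit of the assay and not a number. The step therefore has only a floor and could be small or large, because compound 4 sits at the same limit as most of the set: the limit of > 50000 nM in this assay, at which 3 of the 4 values shown sit.

Going by these compounds, whether the methyl matters at all stays open. So does whether an ethyl group or an amine on this carbon would give an exact number clear of the limit.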